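Taking the methyl group off compound 3

The source may hold more compounds than are shown below. What is called first, only, known or untested is meant among the compounds shown, and "the series" means these compounds.

In a functional assay on Vero cells (Chlorocebus sabaeus) for cytotoxicity (a lower number here means a stronger inhibitor, a higher number a weaker inhibitor), compound 1 (`Cc1cn([C@@H]2C=C[C@H](CO)C2)c(=O)[nH]c1=O`) gives 49400 nM as its reading, and compound 3 (`Cc1cn(C2CCC(CO)C2)c(=O)[nH]c1=O`) gives 171000 nM as the higher of the two actual numbers, a gap beyond the scatter. Compound 2 (`O=c1ccn([C@@H]2C=C[C@H](CO)C2)c(=O)[nH]1`) has no actual number, only > 100000 nM as a limit. Compound 4 (`O=c1ccn(C2CCC(CO)C2)c(=O)[nH]1`) differs from compound 3 by one change (hydrogen in place of methyl on an aromatic carbon), hydrogen in place of methyl on an aromatic carbon. As far as these compounds go, the same swap has been measured only once, as an at least 2.0-fold higher number from compound 1 to compound 2 (0.30 log units; that floor lies within the scatter) in this assay, and that reading rests on the limit of > 100000 nM in this assay, at which 1 of the 3 values shown sits, so its true size stays open. For the measured compounds named here, only this one step bears on the change, so a move towards a higher number is expected, of a size near that floor and quite uncertain. The step expected is a 2.0-fold higher number from compound 3 to compound 4 (0.30 log units; within the scatter) on this reasoning. For compound 4 the estimate is 340000 nM (expected range 170000 nM to 800000 nM).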

Compound 4, half-maximal inhibitory concentration: > 100000 nM
Compound 4 gave a limit, no number (the forecaster's own chance of this, stated with the estimate: 60%); the middle value lies beyond the limit too.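

For the compounds shown here, compound 4 reads > 100000 nM in this assay, which is a limit and not a number, so no step from compound 3 to compound 4 can be read. The true size of swapping methyl for hydrogen stays open for compound 1 with compound 2 and for compound 3 with compound 4, and both pairs share one reason: the limit of > 100000 nM in this assay, at which 2 of the 4 values shown sit.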